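Removing the methoxy from the aryl ether chain end

The source may hold more compounds than are shown below. What is called first, only, known or untested is meant among the compounds shown, and "the series" means these compounds.

Compound 2 `COc1ccc(CCCCCCCCOc2ccc(CSc3cccc(N)c3)nc2/C=C/C(=O)O)cc1` stands at the low end of the three numbers gathered so far. In an assay for binding affinity to leukotriene B4 receptor 1 (Homo sapiens) (a lower number here means a stronger inhibitor, a higher number a weaker inhibitor), compound 2 gives 34 nM; compound 1 `COc1ccc(CCCCCCCCOc2ccc(C[S+]([O-])c3ccccc3)nc2/C=C/C(=O)O)cc1` gives 37 nM, and compound 3 `COc1ccc(CCCCCCCCOc2ccc(C[S+]([O-])c3cccc(OC)c3)nc2/C=C/C(=O)O)cc1` gives 232 nM. The step of a 1.1-fold lower number from compound 1 to compound 2 (0.04 log units; within the scatter) is within the scatter, so compound 2 and compound 1 are not told apart, while a 6.8-fold higher number from compound 2 to compound 3 (0.83 log units; beyond the scatter) and a 6.3-fold higher number from compound 1 to compound 3 (0.80 log units; beyond the scatter) are modest and beyond the scatter.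

Compound 4 `Nc1cccc(SCc2ccc(OCCCCCCCCc3ccccc3)c(/C=C/C(=O)O)n2)c1` differs from compound 2 in one place: hydrogen in place of methoxy on an aromatic carbon, which reads as 4-methoxyphenyl to phenyl, para to a large group. Going by the values given here, none of the measured steps touches this part of the shared core. The step of a 6.3-fold higher number from compound 1 to compound 3 (0.80 log units; beyond the scatter) does concern a methoxy, but on the ring bound to the sulfur, not on the ring at the end of the chain, and it adds rather than removes the group. Among the compounds with values here, there is therefore no measured step that bears directly on the change from compound 2 to compound 4, and no step beyond the scatter is expected in this assay. Compound 4 is estimated at 42 nM, with a range from 15 nM to 120 nM, which means an expected step of a 1.2-fold higher number from compound 2 to compound 4 (0.09 log units; within the scatter).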

Compound 4, inhibition constant: 36 nM
Estimate against measurement, compound 4: 1.2-fold (0.07 log units) above; measured number inside the range.
By their numbers in this assay, from the lowest: compounds 2, 4 and 1 (each within the scatter of the next); then compound 3.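

In this assay, taking the methoxy off the end of the chain, 4-methoxyphenyl to phenyl, gives a 1.1-fold higher number from compound 2 to compound 4 (0.02 log units; within the scatter). Going by these compounds alone, this is the first measured change at this place, para to a large group, and it shows that hydrogen and methoxy here are not told apart in this assay, so the methoxy at the chain end is not needed to hold the number in the range of compound 2. It also shows that the exchange of hydrogen and methoxy does not carry one size from one part of these molecules to another, since the step on the core of compound 1 is far from the one seen here: the same change on two cores in this assay, a 6.3-fold higher number (0.80 log units; beyond the scatter) from compound 1 to compound 3 and a 1.1-fold lower number (0.02 log units; within the scatter) from compound 4 to compound 2, 6.6-fold (0.82 log units) apart, beyond the scatter of two such steps.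

The compounds shown leave open whether the gap between these two steps follows from the place of the methoxy or from the other differences between the cores, since the sulfur-bearing part of compound 4 differs from that of compound 1. They also leave open whether a hydroxyl, a chlorine or a carboxylic acid at the chain end, or a shorter chain in place of the eight-carbon one, would be tolerated as well as hydrogen and methoxy are.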